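Aniline swap on the shared core: compound 2 to compound 4

The source may hold more compounds than are shown below. What is called first, only, known or untested is meant among the compounds shown, and "the series" means these compounds.

Working notes on the aryl amine series. Compound 1 `CN(c1cccc2c1CN(c1nc(Nc3ccc(Cl)c(C(F)(F)F)c3)ncc1C(F)(F)F)C2)S(C)(=O)=O` in a functional assay on A549 cells (Homo sapiens) for antiproliferative activity, read by spectrophotometry, with a stated time of 2 days (a higher number here means a weaker inhibitor of growth, a lower number a stronger inhibitor of growth), gives 15200 nM. Compound 3 `COc1cc(N2CCN(C(C)=O)CC2)ccc1Nc1ncc(C(F)(F)F)c(N2Cc3cccc(N(C)S(C)(=O)=O)c3C2)n1` in this assay gives 3300 nM. Compound 2 `COc1ccc(C(F)(F)F)cc1Nc1ncc(C(F)(F)F)c(N2Cc3cccc(N(C)S(C)(=O)=O)c3C2)n1` is reported in this assay only as a limit, > 30000 nM. Compound 2 thus stands at the limit of > 30000 nM in this assay, at which 1 of the 3 values shown sits, with no number of its own. Among the compounds with values here, the one measured step that bears on the next change is an at least 1.9-fold higher number from compound 1 to compound 2 (0.29 log units; that floor lies within the scatter). Compound 4 `CN(c1cccc2c1CN(c1nc(Nc3cc(Cl)cc(C(F)(F)F)c3)ncc1C(F)(F)F)C2)S(C)(=O)=O` differs from compound 2 in 3-chloro-5-(trifluoromethyl)phenyl in place of 2-methoxy-5-(trifluoromethyl)phenyl on a nitrogen on an aromatic ring. Because compound 1, bearing 4-chloro-3-(trifluoromethyl)phenyl, gives 15200 nM, compound 4 is expected to fall near that region, an expected step of an at least 2.0-fold lower number from compound 2 to compound 4 (0.30 log units; that floor lies within the scatter) in this assay. The estimate for compound 4 is 15000 nM, with a range from 5000 nM to 40000 nM.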

Compound 4, concentration for 50% growth inhibition: 6700 nM
Estimate against measurement, compound 4: 2.2-fold (0.35 log units) above, and the stated range covers the measured number.
By their numbers in this assay, from the lowest: compound 3; then compound 4; then compound 1. At a limit, above all of these: compound 2.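

In this assay, 3-chloro-5-(trifluoromethyl)phenyl in place of 2-methoxy-5-(trifluoromethyl)phenyl gives an at least 4.4-fold lower number from compound 2 to compound 4 (0.65 log units; beyond the scatter), so a change on this nitrogen now shows a step beyond the scatter. Compound 2 is reported only as a limit: the limit of > 30000 nM in this assay, at which 1 of the 4 values shown sits. The arrangement of chlorine and trifluoromethyl on the phenyl ring also registers, with a 2.3-fold lower number from compound 1 to compound 4 (0.36 log units; beyond the scatter).

As far as these compounds go, it remains open whether loss of the methoxy or gain of the chlorine carries the step from compound 2. Also open, from the compounds shown here alone, is how an amine in place of the chlorine of compound 4 would read.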